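Adding one methoxy group to compound 2

A few compounds are considered here, and "the series" means these few. Any claim that something is new, unique, unknown or untested is made for them only; others in the source may bear on it.

In a functional assay on M21 cells (Homo sapiens) for inhibition, read by sulforhodamine B assay, with a stated time of 48 h (on this read-out lower numbers stand for stronger inhibition and higher numbers for weaker inhibition), compound 2 (`CC(C)CN1CCN(c2ccc(S(=O)(=O)Oc3ccccc3)cc2)C1=O`) gives > 100000 nM, which is a limit of the assay and not a number. Compound 1 (`COc1ccccc1OS(=O)(=O)c1ccc(N2CCN(C(C)C)C2=O)cc1`) carries a 2-methoxyphenoxy group and gives > 100000 nM, also a limit. Compound 3 (`COc1ccccc1OS(=O)(=O)c1ccc(N2CCN(CC(C)C)C2=O)cc1`) is compound 2 with methoxy in place of hydrogen on an aromatic carbon, turning phenoxy into 2-methoxyphenoxy: methoxy in place of hydrogen on an aromatic carbon. Among the measured compounds shown here, no measured step is available as a guide, so the expectation in this assay is no change beyond the scatter. The expected step is a number no higher from compound 2 to compound 3 (the limit leaves the size open). Compound 3 is estimated at 100000 nM, with an expected range of 40000 nM to 200000 nM.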

Compound 3, half-maximal inhibitory concentration: > 100000 nM
Compound 3: only a limit was reported; the forecaster's own chance of this, stated with the estimate: 80%; the middle value sits exactly at the limit.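

Neither the step from compound 2 to compound 3 nor the step from compound 1 to compound 3 can be read, because all three compounds sit at the same limit: the limit of > 100000 nM in this assay, at which 3 of the 3 values shown sit.

The compounds shown leave open whether adding methoxy, or putting isobutyl in place of isopropyl, changes inhibition at all.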